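A Chloro Added to the Core of Compound 1

The source may report more compounds than this note shows. Statements on the series, on what has been measured and on what is new or still open speak of the compounds shown alone.

Compound 1, `Clc1ccccc1COc1ccccc1/C=C/C(/C=C/c1ccccn1)=N/Oc1ncnc2ccccc12`: 96% in a functional assay on SMMC-7721 cells (Homo sapiens) for inhibition, read by MTT assay, with a stated time of 72 h, tested at 10 uM; a lower number here means a weaker effect, a higher number a stronger effect of the compound at the concentration tested
Compound 2, `Clc1ccc(COc2ccc(/C=C/C(/C=C/c3ccccn3)=N/Oc3ncnc4ccccc34)cc2)c(Cl)c1`: 89.6%
Compound 3, `Cc1cccc(COc2ccc(/C=C/C(/C=C/c3ccccn3)=N/Oc3ncnc4ccccc34)cc2)c1`: 97.5%

All three measured compounds share one core and differ only in the group attached through the saturated chain carbon bound to an oxygen on an aromatic ring. Their numbers lie close together: compound 1 sits between compound 2 and compound 3, and each gap is within the usual scatter, so none of the three can be called stronger or weaker than another.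

Compound 4, `Clc1ccc2c(O/N=C(\C=C\c3ccccn3)/C=C/c3ccccc3OCc3ccccc3Cl)ncnc2c1`, differs from compound 1 in a different part of the molecule: chloro in place of hydrogen on an aromatic carbon. Read one bond further out, the change is quinazolin-4-yl to 7-chloroquinazolin-4-yl, that is, on the shared core rather than on the side group.

For the measured compounds named here, only one measured step exists, a number 7.9 percentage points higher from compound 2 to compound 3 (within the scatter), and it concerns the side group, not the core, and is itself within the scatter. Going by the values given here, no measured step touches the place where the chloro enters, so nothing measured bears directly on this change. What the data do show is that every variant tested so far gives high inhibition. On that basis the step of a number 3 percentage points lower from compound 1 to compound 4 (within the scatter) is expected to stay within the scatter, with compound 4 estimated at 93%, in a range from 78% to 99%.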

Compound 4, a percentage reported as inhibition, at one concentration (the size of the read-out at that concentration, not a potency): 94.5%
The estimate for compound 4 lay 1.5 percentage points below the measured number, within the range that was stated.
By their numbers in this assay, from the lowest: compounds 2, 4, 1 and 3 (each within the scatter of the next).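

Replacing quinazolin-4-yl with 7-chloroquinazolin-4-yl gives a number 1.5 percentage points lower from compound 1 to compound 4 (within the scatter) in this assay, so this assay cannot tell compound 1 and compound 4 apart. For the compounds shown here, this is the first measured change on the shared core rather than on the side group, and it shows that high inhibition persists with a chloro on this aromatic carbon, meta to a fused ring and para to a fused ring. The read-out is the size of the effect at one concentration and not a potency, so the result shows no difference at that concentration but cannot rule out a difference in potency, and no supporting data explain the outcome.

As far as these compounds go, whether this carbon would give similar numbers with a different group, such as a methoxy group, an amine or a carboxylic acid, remains open. Also open is whether the 7-chloroquinazolin-4-yl core would give similar numbers when combined with the side groups of compound 2 and compound 3, since the chloro is shown here with the side group of compound 1 only.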